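The compounds below may be only part of what the source reports. "The series", "measured", "known", "first", "only" and "open" are said of these compounds alone.

Measured compounds:
compound 1, `OC[C@H]1O[C@@H](n2cnc3c(NCc4ccc(F)cc4)ncnc32)[C@H](O)[C@@H]1O`, 1200 nM;
compound 2, `Cc1cccc(CNc2ncnc3c2ncn3[C@@H]2O[C@H](CO)[C@@H](O)[C@H]2O)c1`, 6400 nM;
compound 3, `OC[C@H]1O[C@@H](n2cnc3c(NCc4ccc(F)c(F)c4F)ncnc32)[C@H](O)[C@@H]1O`, 13000 nM.

All three were tested in a functional assay on HL-60 cells (Homo sapiens) for antiproliferative activity, with a stated time of 72 h; on this read-out lower numbers stand for stronger inhibition and higher numbers for weaker inhibition. Compound 2 stands second highest of the three numbers, with compound 3 nearest (a 2.0-fold higher number from compound 2 to compound 3 (0.31 log units; beyond the scatter)) and compound 1 furthest (a 5.3-fold higher number from compound 1 to compound 2 (0.73 log units; beyond the scatter)). The unmeasured compound 4 is `OC[C@H]1O[C@@H](n2cnc3c(NCc4ccc(F)c(Cl)c4)ncnc32)[C@H](O)[C@@H]1O`; it differs from compound 2 by 3-chloro-4-fluorophenyl in place of 3-methylphenyl on a saturated chain carbon bound to a nitrogen on an aromatic ring. Going by the values given here, the steps that bear on this are a 5.3-fold higher number from compound 1 to compound 2 (0.73 log units; beyond the scatter) and an 11-fold higher number from compound 1 to compound 3 (1.03 log units; beyond the scatter): the 4-fluorophenyl of compound 1 gave the lowest number, and the 3-methylphenyl of compound 2 a higher one. Since compound 4 carries both a fluorine and a chlorine on the ring, the estimate for compound 4 is a modest step down, a 2.1-fold lower number from compound 2 to compound 4 (0.33 log units; beyond the scatter), to 3000 nM, expected within 1000 nM to 10000 nM.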

Compound 4, half-maximal inhibitory concentration: 3500 nM
Compound 4: the middle estimate sits 1.2-fold (0.07 log units) below what was measured, within the range that was stated.
By their numbers in this assay, from the lowest: compound 1; then compounds 4 and 2 (each within the scatter of the next); then compound 3.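

In this assay chloro in place of hydrogen on the 4-fluorophenyl raises the number (a 2.9-fold higher number from compound 1 to compound 4 (0.46 log units; beyond the scatter)), so adding this second halogen does not keep the activity of compound 1. The 3-chloro-4-fluorophenyl still does better than the 2,3,4-trifluorophenyl (a 3.7-fold lower number from compound 3 to compound 4 (0.57 log units; beyond the scatter)), which shows that the kind and number of halogens on this ring count, while the change from 3-methylphenyl stays within the scatter (a 1.8-fold lower number from compound 2 to compound 4 (0.26 log units; within the scatter)). Nothing at hand gives a reason for these differences. As far as these compounds go, whether a methoxy group on the ring, or a longer chain in place of the benzyl link, would reach a number lower than that of compound 1 stays open.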